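A few compounds are considered here, and "the series" means these few. Any claim that something is new, unique, unknown or untested is made for them only; others in the source may bear on it.

Compound 1, `CC1=C(C(=O)Nc2ccc([N+](=O)[O-])cc2)C(c2cccc([N+](=O)[O-])c2)N=C(SCc2ccccc2)N1`: in a functional assay on the whole organism (artery, strain albino) with Rattus norvegicus as the target, with a stated time of 15 min, at a dose of 10 mg/kg by the oral route (a higher number here means more inhibition at the dose given (going by the name of the read-out), a lower number less inhibition), compound 1 gives 2.6%.
Compound 2, `CC1=C(C(=O)Nc2ccc([N+](=O)[O-])cc2)C(c2cccc([N+](=O)[O-])c2)N=C(SCc2ccccc2Cl)N1`: in this assay compound 2 gives 2.1%.

Among the compounds with values here, of the two numbers measured so far, the one for compound 2 is the lower, but the step of a number 0.5 percentage points lower from compound 1 to compound 2 (within the scatter) lies within the scatter, so the two compounds cannot be told apart on these data. Compound 3, `CC1=C(C(=O)Nc2ccc([N+](=O)[O-])cc2)C(c2cccc([N+](=O)[O-])c2)N=C(SCc2cccc(Cl)c2)N1`, differs from compound 2 in one place: 3-chlorophenyl in place of 2-chlorophenyl on a saturated chain carbon bound to a sulfur.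

Within the data shown here, only one measured step bears on this change. It is the step of a number 0.5 percentage points lower from compound 1 to compound 2 (within the scatter), in which a chloro replaced hydrogen on the same benzyl ring, and it stayed within the scatter. Among the measured compounds shown here, no measured step shows what moving a chlorine from one place on that ring to another does. For the measured compounds named here, on the evidence in hand, then, the shift from the 2-chlorobenzyl to the 3-chlorobenzyl group is expected to give no step in this assay beyond the scatter. Compound 3 is therefore estimated at 2.5%, with a range from -8% to 12%. The expected step is a number 0.4 percentage points higher from compound 2 to compound 3 (within the scatter).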

Compound 3, a percentage reported as inhibition, in the whole organism at one dose (the size of the read-out at that dose, not a potency): 2.6%
Compound 3: the middle estimate sits 0.1 percentage points below what was measured; the range from low to high includes it.
By their numbers in this assay, from the lowest: compounds 2, 1 and 3 (each within the scatter of the next).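

In this assay, moving the chlorine from the 2-chlorobenzyl to the 3-chlorobenzyl arrangement on the sulfur gives a number 0.5 percentage points higher from compound 2 to compound 3 (within the scatter), so these two placements of the chlorine on the ring cannot be told apart. Within the data shown here, the earlier compounds showed only that the 2-chlorophenyl group could not be distinguished from the plain benzyl compound; the comparison with that compound now gives no change at the digits printed from compound 1 to compound 3 (within the scatter), so the 3-chlorophenyl group cannot be distinguished from it either, and all three compounds sit together on this read-out. Nothing available bears on why these substitutions leave the result as it is.

The compounds shown carry only a benzyl group, with or without one chlorine, on the sulfur of an otherwise identical core, so it remains open whether this position can move the inhibition at this dose at all. On these data alone, a longer chain, an amine or a carboxylic acid in place of the benzyl group would test that more widely than shifting a chlorine does, and the effect of changing the shared core also remains unknown.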